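A few compounds are considered here, and "the series" means these few. Any claim that something is new, unique, unknown or untested is made for them only; others in the source may bear on it.

In a functional assay on MCF7 cells (Homo sapiens) for cytotoxicity, read by MTT assay, with a stated time of 72 h (a higher number here means a weaker inhibitor, a lower number a stronger inhibitor), three compounds that share one core and differ only in the group on a carbon with a double bond to nitrogen give very similar numbers. Compound 1 `COc1cc2ncnc(Nc3ccc(F)c(Cl)c3)c2cc1NC(=O)N/N=C/c1ccc(F)cc1` gives 35100 nM, compound 2 `COc1cc2ncnc(Nc3ccc(F)c(Cl)c3)c2cc1NC(=O)N/N=C/c1cccc(Cl)c1Cl` gives 28700 nM, and compound 3 `COc1cc2ncnc(Nc3ccc(F)c(Cl)c3)c2cc1NC(=O)N/N=C/c1cc(Br)c(O)c(Br)c1` gives 30200 nM. Compound 3 therefore lies within the scatter of both of the others, and no order can be drawn among them.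

Compound 4 `COc1cc2ncnc(Nc3ccc(F)c(Cl)c3)c2cc1NC(=O)N/N=C/c1ccc(O)cc1O` has not yet been measured. It carries 2,4-dihydroxyphenyl in place of 3,5-dibromo-4-hydroxyphenyl at that same carbon: 2,4-dihydroxyphenyl in place of 3,5-dibromo-4-hydroxyphenyl on a carbon with a double bond to nitrogen.

Three measured swaps at this place bear on the change: a 1.2-fold lower number from compound 1 to compound 2 (0.09 log units; within the scatter), a 1.2-fold lower number from compound 1 to compound 3 (0.07 log units; within the scatter) and a 1.1-fold higher number from compound 2 to compound 3 (0.02 log units; within the scatter). All three stay within the scatter, so no shift beyond it is expected here. The expected change is a 1.0-fold lower number from compound 3 to compound 4 (0.00 log units; within the scatter), an estimate with no clear direction. Among the compounds with values here, none of the measured compounds carries 2,4-dihydroxyphenyl, so the range is kept wide. For compound 4 the estimated value is 30000 nM, with an expected range of 15000 nM to 60000 nM.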

Compound 4, half-maximal inhibitory concentration: 36200 nM
Estimate against measurement, compound 4: 1.2-fold (0.08 log units) below; low and high end bracket the measured number.
By their numbers in this assay, from the lowest: compounds 2, 3, 1 and 4 (each within the scatter of the next).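

Three steps place compound 4 among the others in this assay and each stays within the scatter: a 1.2-fold higher number from compound 3 to compound 4 (0.08 log units; within the scatter) then a 1.3-fold higher number from compound 2 to compound 4 (0.10 log units; within the scatter) and a 1.0-fold higher number from compound 1 to compound 4 (0.01 log units; within the scatter) as well. Compound 4 is the only one of the four whose group, 2,4-dihydroxyphenyl, carries no halogen, and that group has 2 hydrogen-bond donors where 3,5-dibromo-4-hydroxyphenyl has 1. Among these four compounds, then, having halogen on this ring or none makes no difference beyond the scatter.

From the compounds shown here alone, all four compounds place a six-membered aromatic ring of carbon only at this carbon, so it remains open whether an amine, a carboxylic acid or a plain alkyl chain there would move the number beyond the scatter. Nothing measured here explains why these groups give such similar numbers.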